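Swapping amino for methoxy on a cytotoxic chalcone-pyrazole

A few compounds are considered here, and "the series" means these few. Any claim that something is new, unique, unknown or untested is made for them only; others in the source may bear on it.

Compound 1 `COc1cc(-c2cc(/C=C/C(=O)c3ccc(N)cc3)[nH]n2)cc(OC)c1OC` is the most strongly acting of three compounds tested in a functional assay on HOP-62 cells (Homo sapiens) for cytotoxicity, read by sulforhodamine B assay, with a stated time of 48 h, tested at 10 uM (on this read-out higher numbers stand for a weaker effect at the one concentration tested and lower numbers for a stronger effect), where compound 1 gives -59%. Compound 3 `COc1ccc(-c2cc(/C=C/C(=O)c3cc(OC)c(OC)c(OC)c3)[nH]n2)cc1OC` gives -57%, so close that the two cannot be told apart. For the measured compounds named here, compound 2 `COc1ccc(-c2cc(/C=C/C(=O)c3ccc(N)cc3)[nH]n2)cc1OC` gives -1%, and the only single-point step among them, a number 58 percentage points higher from compound 1 to compound 2 (beyond the scatter), shows that taking away one methoxy group on the aryl ring attached to the shared core wipes out almost the whole effect.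

Compound 4 `COc1ccc(C(=O)/C=C/c2cc(-c3cc(OC)c(OC)c(OC)c3)n[nH]2)cc1` keeps that trimethoxyphenyl side untouched and changes the other end: methoxy in place of amino on an aromatic carbon. Going by the values given here, no measured step covers this exchange; the step from compound 1 to compound 2 concerns a different ring and says nothing direct about it. The values of compound 2 and compound 3 show that the aryl ring on the ketone side can be altered heavily while a strong effect is retained, provided the trimethoxyphenyl half is present. Since compound 4 keeps that half, the effect is expected to stay largely in place, with room for some loss, giving an expected step of a number 17 percentage points higher from compound 1 to compound 4 (beyond the scatter). For compound 4 the estimate is -42%, in the range -70% to 0%.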

Compound 4, a percentage reported as activity, at one concentration (the size of the read-out at that concentration, not a potency): -64%
Compound 4: the middle estimate sits 22 percentage points above what was measured; the measured number falls inside the stated range.
By their numbers in this assay, from the lowest: compounds 4, 1 and 3 (each within the scatter of the next); then compound 2.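

In this assay, exchanging 4-aminophenyl for 4-methoxyphenyl gives a number 5 percentage points lower from compound 1 to compound 4 (within the scatter) and so leaves the read-out unchanged within the usual scatter, the first sign that this place, para to a large group, accepts more than one substituent without losing the strong effect. The earlier single-place step a number 58 percentage points higher from compound 1 to compound 2 (beyond the scatter) showed only that the effect is sensitive to a change at the other end of the molecule, whereas this step shows a change at the amino end that costs nothing measurable, even though amino carries a hydrogen-bond donor and methoxy carries none. Nothing measured here explains why the two groups behave alike at this place.

Only amino and methoxy are shown at this position, so it remains open whether a hydroxyl group, a fluorine atom, a carboxylic acid or a plain hydrogen would keep the effect as well. On these data alone, because the read-out comes from a single concentration, it also remains open whether compound 1 and compound 4 would still look alike across a range of concentrations.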